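Replacing a Dibutylamino Tail with a (tert-Butyl)amino Group

A few compounds are considered here, and "the series" means these few. Any claim that something is new, unique, unknown or untested is made for them only; others in the source may bear on it.

Compound 1 `CCCCN(CCCC)CCCOc1ccc(S(=O)(=O)c2c(C(C)C)n(C)c3ccccc23)cc1` and compound 3 `CCCCN(CCCC)CCCOc1ccc(S(=O)(=O)c2c(C(C)C)nn3ccccc23)cc1` carry the same side chain on different cores; the difference between the two cores is not broken down here. In a functional assay (aorta) for inhibition, with Rattus norvegicus as the target (a lower number here means a stronger inhibitor, a higher number a weaker inhibitor), compound 1 gives 24.1 nM, and compound 3 gives 31.1 nM. Compound 2 `CC(C)c1nn2ccccc2c1S(=O)(=O)c1ccc(OCCCNC(C)(C)C)cc1` differs from compound 3 by (tert-butyl)amino in place of dibutylamino on a saturated chain carbon, three bonds along the chain from an oxygen on an aromatic ring. In this assay compound 2 gives 168 nM, which amounts to a 5.4-fold higher number from compound 3 to compound 2 (0.73 log units; beyond the scatter). Compound 4 `CC(C)c1c(S(=O)(=O)c2ccc(OCCCNC(C)(C)C)cc2)c2ccccc2n1C` makes the same change on the core of compound 1: (tert-butyl)amino in place of dibutylamino on a saturated chain carbon, three bonds along the chain from an oxygen on an aromatic ring. Because a 5.4-fold higher number from compound 3 to compound 2 (0.73 log units; beyond the scatter) was measured for this same change at an identical place, a step of a similar size is expected, namely a 5.4-fold higher number from compound 1 to compound 4 (0.73 log units; beyond the scatter). Compound 4 is therefore expected to give about 130 nM in this assay, most likely between 60 nM and 300 nM.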

Compound 4, half-maximal inhibitory concentration: 99.3 nM
The estimate for compound 4 lay 1.3-fold (0.12 log units) above the measured number; low and high end bracket the measured number.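

In this assay putting (tert-butyl)amino in place of dibutylamino gives a 4.1-fold higher number from compound 1 to compound 4 (0.61 log units; beyond the scatter) and so moves the number in the same direction as on the other core. The two steps match in size: the same change on two cores in this assay, a 5.4-fold higher number (0.73 log units; beyond the scatter) from compound 3 to compound 2 and a 4.1-fold higher number (0.61 log units; beyond the scatter) from compound 1 to compound 4, 1.3-fold (0.12 log units) apart, within the scatter of two such steps

The change therefore carried over between these two cores with much the same size, but two cores are too few to show that it would do so on every core in the series, and these numbers do not explain why the number rises. The compounds shown leave open how a different tail, such as a piperidine ring, a dimethylamino group or a primary amine, would behave in this assay on these cores. They also leave open what a longer chain between the oxygen and the amine would do.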